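Ortho substituent swap on the anilino-thiazole series

A few compounds are considered here, and "the series" means these few. Any claim that something is new, unique, unknown or untested is made for them only; others in the source may bear on it.

Measured so far:
compound 1 `Cc1cc(C)cc(Nc2nc(-c3ccncc3)cs2)c1` 4570 nM
compound 2 `FC(F)(F)c1ccccc1Nc1nc(-c2ccncc2)cs1` 40700 nM

In a functional assay on RCC4 cells (Homo sapiens) for inhibition, read by XTT assay, with a stated time of 4 days (a higher number here means a weaker inhibitor, a lower number a stronger inhibitor), compound 2 gives 40700 nM, the higher of the two numbers; compound 1 sits below it, and the gap between them lies beyond the scatter. Compound 3 `O=[N+]([O-])c1ccccc1Nc1nc(-c2ccncc2)cs1` is not yet measured. Relative to compound 2 the change is nitro in place of trifluoromethyl on an aromatic carbon. Within the data shown here, no measured pair shows this change, so the size of the step is open. A modest step toward a lower number is expected, a 2.0-fold lower number from compound 2 to compound 3 (0.31 log units; beyond the scatter), though one within the scatter would not surprise. For compound 3 the estimate is 20000 nM, from 5000 nM to 80000 nM.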

Compound 3, half-maximal inhibitory concentration: 40700 nM
The estimate for compound 3 lay 2.0-fold (0.31 log units) below the measured number; low and high end bracket the measured number.
By their numbers in this assay, from the lowest: compound 1; then compounds 2 and 3 (each within the scatter of the next).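

In this assay, nitro in place of trifluoromethyl on an aromatic carbon, ortho to a large group, gives no change at the digits printed from compound 2 to compound 3 (within the scatter). At this position, the two groups cannot be told apart by this read-out, even though nitro brings 2 hydrogen-bond acceptors and trifluoromethyl has 0. No measured evidence bears on why the two groups read alike. The compounds shown leave open whether an amine or a carboxylic acid on this same aromatic carbon would shift the number. From the compounds shown here alone, how either group compares with plain hydrogen there also remains open.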